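Swapping the aryl group on the alkyne of a weak antiproliferative

The compounds below may be only part of what the source reports. "The series", "measured", "known", "first", "only" and "open" are said of these compounds alone.

Compound 1 `O=c1[nH]c(=O)n(CCC(CO)CO)cc1-c1ccco1`: 500 nM
Compound 2 `CC(=O)OCC(CCn1cc(C#Cc2cc(F)cc(F)c2)c(=O)n(C(=O)c2ccccc2)c1=O)COC(C)=O`: 46600 nM

Within the data shown here, in an ADME assay on BJ cells (Homo sapiens) for antiproliferative activity, read by MTT assay, with a stated time of 72 h (on this read-out higher numbers stand for weaker inhibition and lower numbers for stronger inhibition), compound 2 gives 46600 nM, the highest of the two numbers, while compound 1 gives 500 nM, a far lower number; no single structural step links these two compounds. Compound 3 `CC(=O)OCC(CCn1cc(C#Cc2ccc(Br)cc2)c(=O)n(C(=O)c2ccccc2)c1=O)COC(C)=O` differs from compound 2 in one place: 4-bromophenyl in place of 3,5-difluorophenyl on a triple-bonded carbon. Among the measured compounds shown here, no measured pair shows what such a swap does here, so the expected step of a 1.3-fold lower number from compound 2 to compound 3 (0.12 log units; within the scatter) is small and uncertain in direction, most likely within the scatter. Compound 3 is therefore estimated at 35000 nM, with a range from 10000 nM to 120000 nM.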

Compound 3, half-maximal inhibitory concentration: 37600 nM
Beside the measured number, compound 3's estimate is 1.1-fold (0.03 log units) below it, within the range that was stated.
By their numbers in this assay, from the lowest: compound 1; then compounds 3 and 2 (each within the scatter of the next).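

In this assay the step is a 1.2-fold lower number from compound 2 to compound 3 (0.09 log units; within the scatter), so at this position on a triple-bonded carbon, 4-bromophenyl and 3,5-difluorophenyl cannot be told apart. This first measured pair shows that exchanging one halogen-bearing phenyl group for another, even with a different halogen and a different count of halogens, leaves the number within the scatter. No measurement offered here explains this result. Still open, as far as these compounds go, is whether a group of another kind on this carbon, such as an amine or a longer carbon chain, would give a number beyond the scatter.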